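Solubility of a Cyclobutyl Amide in Place of a Fluorophenyl

This account rests on a few compounds, and the source may have more. Where it says the series, first, only, none or still open, it means among the compounds named here.

Compound 1 `O=C(c1ccccc1F)N1CCN(c2nc(=O)c3cc(C(F)(F)F)cc([N+](=O)[O-])c3s2)CC1`: 3.1 ug/mL
Compound 2 `O=C(c1ccc(Cl)cc1)N1CCN(c2nc(=O)c3cc(C(F)(F)F)cc([N+](=O)[O-])c3s2)CC1`: 5.19 ug/mL

For the measured compounds named here, in a physicochemical assay for solubility, read by HPLC (a higher number here means a more soluble compound, a lower number a less soluble compound), compound 1 has the lower of the two numbers measured, with compound 2 the nearest; the one measured step, a 1.7-fold higher number from compound 1 to compound 2 (0.22 log units; within the scatter), puts 4-chlorophenyl in place of 2-fluorophenyl on the carbonyl carbon, and the two compounds are not told apart by it. Compound 3 `O=C(C1CCC1)N1CCN(c2nc(=O)c3cc(C(F)(F)F)cc([N+](=O)[O-])c3s2)CC1` has not yet been measured in this assay. It differs from compound 1 in one place: cyclobutyl in place of 2-fluorophenyl on a carbonyl carbon. Going by the values given here, no measured pair exchanges a six-membered aromatic ring for a four-membered non-aromatic ring, so the single step between the two phenyl amides gives only indirect guidance, and it was small. A modest rise is nonetheless expected for compound 3, as a step of a 1.9-fold higher number from compound 1 to compound 3 (0.29 log units; within the scatter), with wide uncertainty around it. The estimate for compound 3 in this assay is 6 ug/mL, expected to fall between 2 ug/mL and 18 ug/mL.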

Compound 3, solubility: 39.3 ug/mL
Beside the measured number, compound 3's estimate is 6.6-fold (0.82 log units) below it, outside the stated range (above it).
By their numbers in this assay, from the lowest: compounds 1 and 2 (each within the scatter of the next); then compound 3.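

In this assay, putting cyclobutyl in place of a phenyl ring on the carbonyl carbon gives a 13-fold higher number from compound 1 to compound 3 (1.10 log units; beyond the scatter) and a 7.6-fold higher number from compound 2 to compound 3 (0.88 log units; beyond the scatter). Compounds 1 and 2 stood within the scatter of each other, so the exchange of 4-chlorophenyl for 2-fluorophenyl had not shown that this position could move the read-out, whereas the change to cyclobutyl shows that it can. The compounds shown offer no independent measurement that could account for the rise.

On these data alone, it remains open whether the rise is specific to cyclobutyl or would also appear with cyclopropyl, cyclohexyl or an open carbon chain such as butyl. As far as these compounds go, it is also open what a ring carrying an amine, such as piperidine, or a carboxylic acid would do on the same carbonyl carbon.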